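The compounds below may be only part of what the source reports. "The series", "measured", "known", "first", "only" and "open" are said of these compounds alone.

Measured in a physicochemical assay for solubility, in phosphate buffer, measured as kinetic solubility; a higher number here means a more soluble compound, a lower number a less soluble compound:
- compound 1 `CCc1nn2c(-c3cc(OC)c(OC)cc3OC)cccc2c1N(CC1CCOCC1)CC1CC1`: 3600 nM
- compound 2 `COCc1cc(OC)c(-c2cccc3c(N(CC4CC4)CC4OCCCO4)c(SC)nn23)c(OC)c1`: 4100 nM
- compound 3 `COCc1cc(OC)c(-c2cccc3c(N(CC4CCOCC4)CC4CC4)c(C#N)nn23)c(OC)c1`: 1700 nM

Compound 3 has the lowest number of the three in this assay, and the gaps up to compound 1 and compound 2 both lie beyond the scatter. The next compound to read is compound 4 `CCc1nn2c(-c3c(OC)cc(COC)cc3OC)cccc2c1N(CC1CCOCC1)CC1CC1`, which has ethyl in place of cyano on an aromatic carbon.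

Going by the values given here, no two measured compounds differ in one place only, so this assay offers no direct measure of this exchange. The nearest guide is compound 1, which also carries ethyl on that aromatic carbon and gives 3600 nM. It also differs from compound 3 elsewhere, which makes it a loose guide. Among the compounds with values here, with only three values, no pattern can be claimed for the series.

A modest move toward a higher number is expected, though it may not clear the scatter. The estimated change is a 1.6-fold higher number from compound 3 to compound 4 (0.22 log units; within the scatter). For compound 4 the expected value is 2800 nM, with an estimated range of 1300 nM to 6000 nM.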

Compound 4, solubility: 4800 nM
Compound 4: the middle estimate sits 1.7-fold (0.23 log units) below what was measured; the measured number falls inside the stated range.
By their numbers in this assay, from the lowest: compound 3; then compounds 1, 2 and 4 (each within the scatter of the next).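

Going by these compounds alone, compound 3 and compound 4 form the first pair that differs in one place only, so this position can now be read directly. In this assay, ethyl in place of cyano on this aromatic carbon of the five-membered ring gives a 2.8-fold higher number from compound 3 to compound 4 (0.45 log units; beyond the scatter), a step beyond the scatter between two groups that both count 2 heavy atoms. The exchange also removes the triple bond and the 1 hydrogen-bond acceptor counted for cyano, but no measurement here bears on what lies behind the step.

Going by these compounds, this remains one pair, so it is open whether the step would carry over to compounds with a different amino group or a different substitution on the aryl ring than compound 3 and compound 4 share. Also open, on these data alone, is how an aminomethyl group, a carboxylic acid or a longer alkyl chain such as butyl on this same carbon would read against ethyl and cyano, with the (cyclopropylmethyl)((oxan-4-yl)methyl)amino group kept in place.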